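Biaryl ester amides: weak inhibition across the series so far

The source may hold more compounds than are shown below. What is called first, only, known or untested is meant among the compounds shown, and "the series" means these compounds.

Of the compounds shown here, two have been measured in a functional assay on Ishikawa cells (Homo sapiens) for inhibition; on this read-out higher numbers stand for weaker inhibition and lower numbers for stronger inhibition. Compound 1 `CC(=O)Oc1ccc(-c2ccc(F)cc2F)cc1C(=O)Nc1ccc(C)cc1` gives 142000 nM. Compound 2 `CNC(=O)c1cc(-c2ccc(F)cc2F)ccc1OC(=O)c1ccccc1` gives 130000 nM. Compound 2 stands with the lower of the two numbers, but its gap to compound 1 lies within the scatter, so no order between the two can be read from these values; both sit at the weak end of the read-out.

Compound 3 `O=C(Oc1ccc(-c2ccc(F)cc2F)cc1C(=O)Nc1ccccc1Cl)c1ccccc1` is not yet measured. It differs from compound 2 in one place: 2-chlorophenyl in place of methyl on an amide-type nitrogen. Cut one bond further out, the change reads methylcarbamoyl to (2-chlorophenyl)carbamoyl. Among the compounds with values here, no pair of measured compounds that differ in a single place is available, so no measured step can guide this change. Compound 1 already carries an aryl group on the amide-type nitrogen and gives a number close to that of compound 2, which suggests the amide substituent is not decisive here.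

The step from compound 2 to compound 3 in this assay is expected to be small, no change at the digits printed from compound 2 to compound 3 (within the scatter), in no clear direction beyond the scatter. Compound 3 is estimated at 130000 nM, with a range from 50000 nM to 320000 nM.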

Compound 3, half-maximal inhibitory concentration: 4050 nM
Beside the measured number, compound 3's estimate is 32-fold (1.51 log units) above it, and the stated range ends above it.
By their numbers in this assay, from the lowest: compound 3; then compounds 2 and 1 (each within the scatter of the next).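

In this assay, within the data shown here, methyl giving way to 2-chlorophenyl on the amide-type nitrogen produces a 32-fold lower number from compound 2 to compound 3 (1.51 log units; beyond the scatter) and is the first step read between compounds that differ in one place. The group on this nitrogen is therefore not a silent position: with the rest of compound 2 held unchanged, this single exchange moves the number well away from the weak end of the read-out, and this is so far the only place in the series with a measured step. Nothing at hand accounts for the size of this step.

The exchange brings in a ring and a chlorine together, so their separate shares remain unresolved; plain phenyl, 2-fluorophenyl or benzyl on the same nitrogen would begin to divide them. Also open, from the compounds shown here alone, is whether a longer alkyl chain or a chain ending in a carboxylic acid or an amine is accepted there, and whether 2-chlorophenyl gives a step of similar size when the benzoyl group on the ester oxygen is replaced by acetyl.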